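The source may hold more compounds than are shown below. What is called first, only, known or untested is meant among the compounds shown, and "the series" means these compounds.

Measured compounds in the series:

compound 1 `O=S(=O)(NCCCNCc1cccc2ccccc12)c1cc(C(F)(F)F)cc(C(F)(F)F)c1`: 2600 nM
compound 2 `COc1ccc(CNCCCNS(=O)(=O)c2cc(C(F)(F)F)cc(C(F)(F)F)c2)cc1OC`: 2700 nM
compound 3 `O=S(=O)(NCCCNCC1COc2ccccc2O1)c1cc(C(F)(F)F)cc(C(F)(F)F)c1`: 2200 nM

In a functional assay on HT-29 cells (Homo sapiens) for inhibition, read by MTT assay, with a stated time of 72 h (a lower number here means a stronger inhibitor of growth, a higher number a weaker inhibitor of growth), compound 3 shows the lowest of the three numbers, but the steps of a 1.2-fold lower number from compound 1 to compound 3 (0.07 log units; within the scatter) and a 1.2-fold lower number from compound 2 to compound 3 (0.09 log units; within the scatter) both lie within the scatter, as does a 1.0-fold higher number from compound 1 to compound 2 (0.02 log units; within the scatter), so the three groups on a saturated chain carbon bound to an amine nitrogen give numbers that cannot be told apart. Compound 4 `O=S(=O)(NCCCNCc1ccccc1Cl)c1cc(C(F)(F)F)cc(C(F)(F)F)c1` is not yet measured; it differs from compound 3 in one place: 2-chlorophenyl in place of 2,3-dihydro-1,4-benzodioxin-2-yl on a saturated chain carbon bound to an amine nitrogen. All three measured steps exchange the group on a saturated chain carbon bound to an amine nitrogen, and none of them moved the number beyond the scatter. Within the data shown here, no measured compound carries 2-chlorophenyl, so there is no direct precedent for that group itself. On the steps seen so far, no step beyond the scatter is expected from compound 3 to compound 4: a 1.1-fold higher number from compound 3 to compound 4 (0.06 log units; within the scatter). For compound 4 the estimated value is 2500 nM, with an expected range from 1200 nM to 5500 nM.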

Compound 4, concentration for 50% growth inhibition: 20000 nM
Beside the measured number, compound 4's estimate is 8.0-fold (0.90 log units) below it; the whole stated range lies below it.
By their numbers in this assay, from the lowest: compounds 3, 1 and 2 (each within the scatter of the next); then compound 4.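

In this assay the group on a saturated chain carbon bound to an amine nitrogen is not freely exchangeable: 2-chlorophenyl gives a 9.1-fold higher number from compound 3 to compound 4 (0.96 log units; beyond the scatter) and a 7.4-fold higher number from compound 2 to compound 4 (0.87 log units; beyond the scatter) and also a 7.7-fold higher number from compound 1 to compound 4 (0.89 log units; beyond the scatter) although the earlier exchanges at this place all stayed within the scatter. Loss of oxygen from this group does not by itself sort the series, since compound 1 has none in its naphthalen-1-yl group yet stays within the scatter of compound 2 and compound 3. No available evidence accounts for this step.

The step rests on compound 4 alone, so the chlorine and the single aromatic ring cannot be separated as the part that matters. An unsubstituted phenyl or a 2-methoxyphenyl group at this place would help to separate them.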